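Widening a Hydroxylated Ring on a Nitro-Bearing Core

This account rests on a few compounds, and the source may have more. Where it says the series, first, only, none or still open, it means among the compounds named here.

Compound 1 `COc1cc[nH]c1/C=C1\C(=O)Nc2ccc([N+](=O)[O-])c(N3CC[C@H](O)C3)c21` is the stronger of the two compounds measured in a functional assay on RKO cells (Homo sapiens) for antiproliferative activity, read by MTT assay, with a stated time of 5 days; a lower number here means a stronger inhibitor, a higher number a weaker inhibitor; compound 1 gives 37 nM. Compound 2 `COc1cc[nH]c1/C=C1\C(=O)Nc2ccc([N+](=O)[O-])cc21`, which lacks the 3-hydroxypyrrolidin-1-yl group, gives 692 nM in this assay, and the step of a 19-fold higher number from compound 1 to compound 2 (1.27 log units; beyond the scatter) shows how much that group contributes. Compound 3 `COc1cc[nH]c1/C=C1\C(=O)Nc2ccc([N+](=O)[O-])c(N3CCCC(O)C3)c21` has not yet been measured in this assay. It differs from compound 1 in one place: 3-hydroxypiperidin-1-yl in place of 3-hydroxypyrrolidin-1-yl on an aromatic carbon. The five-membered ring becomes a six-membered ring, while the hydroxyl and the ring nitrogen remain. Among the compounds with values here, the only measured step concerns removing the whole group, not changing its size, so it sets a scale but not a direction; a far smaller change is expected, possibly none beyond the scatter. For compound 3 the estimate is 60 nM, within 20 nM to 200 nM. This estimate means an expected step of a 1.6-fold higher number from compound 1 to compound 3 (0.21 log units; within the scatter).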

Compound 3, half-maximal inhibitory concentration: 105 nM
Compound 3: the middle estimate sits 1.8-fold (0.24 log units) below what was measured; low and high end bracket the measured number.
By their numbers in this assay, from the lowest: compound 1; then compound 3; then compound 2.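

In this assay, the size of the ring at this aromatic carbon ortho to a nitro group matters: a 2.8-fold higher number from compound 1 to compound 3 (0.45 log units; beyond the scatter) is a modest loss, though not a large one. The hydroxylated six-membered ring still keeps much of the gain over hydrogen, with a 6.6-fold lower number from compound 2 to compound 3 (0.82 log units; beyond the scatter), so this gain does not require the five-membered ring. No measured evidence on the compounds explains why the two rings differ.

Compound 1 has a defined stereocentre and compound 3 has none, so the step from one to the other cannot separate ring size from stereochemistry. As far as these compounds go, the part played by the hydroxyl also stays open, as would be tested by an unsubstituted piperidin-1-yl group or by morpholin-4-yl at the same carbon.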